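Selenium to sulfur swap on the bis-furoyl isourea core

The source may hold more compounds than are shown below. What is called first, only, known or untested is meant among the compounds shown, and "the series" means these compounds.

Compound 1 `C[Se]/C(=N\C(=O)c1ccco1)NC(=O)c1ccco1` is the reference point of this small set. In a functional assay on HepG2 cells (Homo sapiens) for cytotoxicity, read by MTT assay, with a stated time of 72 h (on this read-out lower numbers stand for stronger inhibition of growth and higher numbers for weaker inhibition of growth), compound 1 gives 760 nM, the lowest of the two numbers recorded. Going by the values given here, the only other measured member, compound 2 `CS/C(=N\C(=O)c1cc2ccccc2s1)NC(=O)c1cc2ccccc2s1`, carries methylsulfanyl in place of the selenium group and benzothiophene-derived acyl groups on both nitrogens; in this assay compound 2 gives 15800 nM, a gap from compound 1 that lies beyond the scatter. Compound 2 differs from compound 1 in more than one place, so no single step can be read from that pair.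

Compound 3 `CS/C(=N\C(=O)c1ccco1)NC(=O)c1ccco1` keeps the core of compound 1 and changes only (a group of 2 heavy atoms (1 carbon, 1 sulfur; no ring) in place of a group of 2 heavy atoms (1 carbon, 1 selenium; no ring), on a carbon with a double bond to nitrogen). Among the compounds with values here, no measured pair in this set isolates that change. Within the data shown here, compound 2 shows that the one measured methylsulfanyl member gives 15800 nM, and that is the sole pointer toward direction, weak as it is. The expectation is a move toward a higher number from compound 1 to compound 3, of moderate size, a 3.9-fold higher number from compound 1 to compound 3 (0.60 log units; beyond the scatter). Compound 3 is accordingly estimated at 3000 nM in this assay, with a range from 900 nM to 12000 nM.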

Compound 3, concentration for 50% growth inhibition: > 100000 nM
Compound 3: only a limit was reported; the forecaster's own chance of this, stated with the estimate: 5%; middle value at least 33-fold (1.52 log units) away from the limit.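

In this assay, compound 3 reaches only a limit of the assay, > 100000 nM, and this entry is not a measured number. The single exchange of the group of 1 carbon and 1 selenium for methylsulfanyl, on a carbon with a double bond to nitrogen whose other neighbours are amide-type nitrogens, gives an at least 130-fold higher number from compound 1 to compound 3 (2.11 log units; beyond the scatter), so this position is now shown to matter strongly on the shared core, which the pair of compound 1 and compound 2 could not show. The step is bounded on one side only, and its full size cannot be read from the compounds shown: the limit of > 100000 nM in this assay, at which 1 of the 3 values shown sits.

Whether the same exchange matters as much with the benzothiophene-derived acyl groups stays open, as compound 2 has no selenium partner among the compounds shown. Also open, on these data alone, is how this carbon tolerates other groups, such as a longer chain on selenium like ethylselanyl or an amine, and whether any of them would keep growth inhibition near that of compound 1.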